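The compounds below may be only part of what the source reports. "The series", "measured", "known", "first", "only" and "open" are said of these compounds alone.

Measured so far in a functional assay on MDA-MB-231 cells (Homo sapiens) for inhibition, read by sulforhodamine B assay; a lower number here means a stronger inhibitor, a higher number a weaker inhibitor:

Compound 1 `COC(=O)CC/C(C)=C/Cc1c(OC)c(C)c2c(c1OCC#CCN1CCN(c3ccc(C)cc3)CC1)C(=O)OC2` gives > 50000 nM, which is a limit of the assay and not a number.
Compound 2 `COC(=O)CC/C(C)=C/Cc1c(OC)c(C)c2c(c1OCC#CCN1CCN(C(c3ccccc3)c3ccccc3)CC1)C(=O)OC2` gives > 50000 nM, also a limit.
Compound 3 `COC(=O)CC/C(C)=C/Cc1c(OC)c(C)c2c(c1OCC#CCN1CCC(C(=O)OC)CC1)C(=O)OC2` gives > 50000 nM, again a limit.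

All three compounds share one core and differ only in the group carried on the amine nitrogen of the six-membered ring at the end of the side chain. Compound 1 stands where the other two stand: the limit of > 50000 nM in this assay, at which 3 of the 3 values shown sit. For the measured compounds named here, because each value is a limit, no step between these measured compounds can be sized, and no measured step is available to build on.

Compound 4 `COC(=O)CC/C(C)=C/Cc1c(OC)c(C)c2c(c1OCC#CCN1CCN(C(=O)C3COc4ccccc4O3)CC1)C(=O)OC2` is the next compound in this series. It carries (2,3-dihydro-1,4-benzodioxin-2-yl)carbonyl in place of 4-methylphenyl on an amine nitrogen in a ring.

With three different groups on that nitrogen all sitting at the limit, the expected step in this assay from compound 1 to compound 4 is none beyond the scatter, and compound 4 is expected most likely to sit at the limit as well. The estimate for compound 4 is 60000 nM, with a range from 20000 nM to 200000 nM. This estimate corresponds to an expected step that the limit leaves unreadable from compound 1 to compound 4.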

Compound 4, half-maximal inhibitory concentration: > 50000 nM
Compound 4: a limit, no number; the forecaster's own chance of this, stated with the estimate: 80%; the middle value lies beyond the limit too.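

Compound 1 and compound 4 each give a limit and not a number, so no step between them can be read: the limit of > 50000 nM in this assay, at which 4 of the 4 values shown sit.

The compounds shown leave open whether any group on this amine nitrogen, or any change elsewhere on the shared core, would give a readable value in this assay.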